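A few compounds are considered here, and "the series" means these few. Any claim that something is new, unique, unknown or untested is made for them only; others in the source may bear on it.

Measured so far:
compound 1, `COc1ccc(-c2cnc(NC(=O)c3cccnc3)n2C)cc1`: > 100000 nM
compound 2, `Cn1c(-c2cccc(C#N)c2)cnc1NC(=O)c1ccc(F)cc1`: > 100000 nM

Both readings come from a toxicity assay on THP-1 cells (Homo sapiens) for inhibition; on this read-out higher numbers stand for lower toxicity in this test and lower numbers for higher toxicity in this test. For compound 1 the reading > 100000 nM is a limit of the assay and not a number. For compound 2 the reading > 100000 nM is likewise a limit of the assay and not a number. Going by the values given here, compound 1 therefore stands at the limit of > 100000 nM in this assay, at which 2 of the 2 values shown sit; nothing separates it from compound 2 on the numbers, and no single-point step between the two is counted, since they differ in more than one place.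

Compound 3, `COc1ccc(-c2cnc(NC(=O)C3CCOCC3)n2C)cc1`, has not been measured. It differs from compound 1 in one place: oxan-4-yl in place of pyridin-3-yl on a carbonyl carbon. The rest of the structure is unchanged.

Given that both measured compounds sit at the limit of > 100000 nM in this assay, at which 2 of the 2 values shown sit, nothing in the data argues that compound 3 should fall off that limit. The step from compound 1 to compound 3 is expected to be a number no higher from compound 1 to compound 3 (the limit leaves the size open), that is, none beyond the scatter. For compound 3 the estimate in this assay is 100000 nM, with a range from 40000 nM to 300000 nM, and most likely the assay will again report only a limit.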

Compound 3, half-maximal cytotoxic concentration: > 100000 nM
Compound 3: no number, only a limit (the forecaster's own chance of this, stated with the estimate: 80%); the middle value lies on the limit itself.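

In this assay compound 3 gives > 100000 nM, a limit of the assay and not a number. Going by these compounds alone, compound 1 also reads only as a limit, so no step between compound 1 and compound 3 can be read. The compounds shown leave open whether any structure in this series would give an actual number in this assay: the limit of > 100000 nM in this assay, at which 3 of the 3 values shown sit.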